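The source may hold more compounds than are shown below. What is called first, only, known or untested is meant among the compounds shown, and "the series" means these compounds.

Values in an ADME assay on CHO cells (Cricetulus griseus) for cytotoxicity, read by MTT assay (a lower number here means that less compound is tolerated, a higher number that more compound is tolerated), so far:
Compound 1 `CN1CCN(CC2CCN(c3nccc4[nH]c(-c5cccc(OC(F)(F)F)c5)nc34)CC2)CC1` gives 950 nM
Compound 2 `CN1CCN(C2CCN(c3nccc4[nH]c(-c5ccc(F)c(C(F)(F)F)c5)nc34)CC2)CC1` gives 4800 nM
Compound 3 `CN1CCN(CC2CCN(c3nccc4[nH]c(-c5ccc(F)c(Cl)c5)nc34)CC2)CC1` gives 850 nM

Compound 3 and compound 1 sit level within the scatter, and both lie well under compound 2, which gives 4800 nM in this series. The next compound, compound 4 `CN1CCN(CC2CCN(c3nccc4[nH]c(-c5ccc(F)c(C(F)(F)F)c5)nc34)CC2)CC1`, has trifluoromethyl in place of chloro on an aromatic carbon, ortho to a fluoro group and meta to a large group, a difference that counts as trifluoromethyl in place of chloro on an aromatic carbon in full. The closest measured evidence is the aryl exchange a 1.1-fold lower number from compound 1 to compound 3 (0.05 log units; within the scatter) within the scatter, which replaces 3-(trifluoromethoxy)phenyl with 3-chloro-4-fluorophenyl. Compound 2 also carries the 4-fluoro-3-(trifluoromethyl)phenyl group, but no single measured change connects it to compound 4, so it only widens the upper side of the expectation. No step beyond the scatter is therefore expected, and the estimated change is a 1.2-fold higher number from compound 3 to compound 4 (0.07 log units; within the scatter) in this assay overall. For compound 4 the estimated value is 1000 nM with an expected range from 500 nM to 2400 nM in this assay.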

Compound 4, half-maximal cytotoxic concentration: 3100 nM
Compound 4: middle estimate off by 3.1-fold (0.49 log units), on the low side, and the stated range ends below it.
By their numbers in this assay, from the lowest: compounds 3 and 1 (each within the scatter of the next); then compounds 4 and 2 (each within the scatter of the next).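

In this assay, the aromatic carbon ortho to a fluoro group and meta to a large group proves sensitive to this exchange: trifluoromethyl in place of chloro gives a 3.6-fold higher number from compound 3 to compound 4 (0.56 log units; beyond the scatter), although the earlier aryl exchange gave only a 1.1-fold lower number from compound 1 to compound 3 (0.05 log units; within the scatter). The 4-fluoro-3-(trifluoromethyl)phenyl group likewise separates from 3-(trifluoromethoxy)phenyl, with a 3.3-fold higher number from compound 1 to compound 4 (0.51 log units; beyond the scatter), while (4-methylpiperazin-1-yl)methyl in place of 4-methylpiperazin-1-yl, with that aryl group held fixed, gives only a 1.5-fold lower number from compound 2 to compound 4 (0.19 log units; within the scatter). Nothing available explains why this exchange moves the number.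

The compounds shown leave open whether a nitrile or a methyl group on this carbon would follow trifluoromethyl or chloro. They also leave open whether the step from chloro to trifluoromethyl would persist in a 3-substituted phenyl without the 4-fluoro group.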